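Compound 3: a benzyl ester after a limit value

A few compounds are considered here, and "the series" means these few. Any claim that something is new, unique, unknown or untested is made for them only; others in the source may bear on it.

Compound 1 `CCN(CC)CCNC(=O)c1ccc(C(CC)(CC)c2ccc(OCC(O)C(C)(C)C)c(C)c2)n1CC`: 490 nM
Compound 2 `CCn1c(C(=O)N(C)CCC#N)ccc1C(CC)(CC)c1ccc(OCC(O)C(C)(C)C)c(C)c1`: > 50000 nM (a limit)
Compound 3 `CCn1c(C(=O)OCc2ccc(F)cc2)ccc1C(CC)(CC)c1ccc(OCC(O)C(C)(C)C)c(C)c1`: not yet measured

In a functional assay on HepG2 cells (Homo sapiens), read by MTT assay, with a stated time of 48 h (a lower number here means a stronger inhibitor, a higher number a weaker inhibitor), compound 2 stands at > 50000 nM, which is a limit of the assay and not a number. The next change puts (4-fluorobenzyl)oxy in place of (2-cyanoethyl)(methyl)amino on a carbonyl carbon. Among the compounds with values here, one measured step bears on this, the large at least 100-fold higher number from compound 1 to compound 2 (2.00 log units; beyond the scatter), which removed (2-(diethylamino)ethyl)amino, and compound 3 lacks that group too. The expected result in this assay is therefore an at least 1.4-fold lower number from compound 2 to compound 3 (0.15 log units; that floor lies within the scatter), with nothing expected beyond the scatter. For compound 3 the estimate is 35000 nM, with an expected range from 8000 nM to 50000 nM.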

Compound 3, half-maximal inhibitory concentration: > 50000 nM
Compound 3 gave a limit, no number; the forecaster's own chance of this, stated with the estimate: 60%; middle value at least 1.4-fold (0.15 log units) away from the limit.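

In this assay compound 3 gives > 50000 nM as a limit of the assay and not a number. A second replacement of (2-(diethylamino)ethyl)amino on the carbonyl carbon, now by (4-fluorobenzyl)oxy, gives an at least 100-fold higher number from compound 1 to compound 3 (2.00 log units; beyond the scatter) and so shows that the large loss is not tied to (2-cyanoethyl)(methyl)amino alone. The step between compound 2 and compound 3 cannot be read, because both sit at the same limit: the limit of > 50000 nM in this assay, at which 2 of the 3 values shown sit. Still open, from the compounds shown here alone, is which part of (2-(diethylamino)ethyl)amino matters at this carbonyl carbon, and whether a tertiary amine on a shorter chain, a primary amine or a carboxylic acid there would restore a measurable value.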